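The compounds below may be only part of what the source reports. "The series", "measured", "known", "first", "only" and "open" are said of these compounds alone.

In a functional assay on the whole organism (artery, strain albino) with Rattus norvegicus as the target, with a stated time of 720 min, at a dose of 10 mg/kg by the oral route (a lower number here means less inhibition, a higher number more inhibition at the dose given (going by the name of the read-out)), compound 1 `CC1=C(C(=O)Nc2ccc([N+](=O)[O-])cc2)C(c2ccc(Br)cc2)N=C(SCc2ccccc2Cl)N1` gives 6.7% and compound 2 `CC1=C(C(=O)Nc2ccc([N+](=O)[O-])cc2)C(c2ccc(Br)cc2)N=C(SCc2cccc(Cl)c2)N1` gives 2.6%. Among the compounds with values here, compound 2 holds the lowest of the two numbers so far, and its nearest neighbour is compound 1, within the scatter. Compound 3 `CC1=C(C(=O)Nc2ccc([N+](=O)[O-])cc2)C(c2ccc(Br)cc2)N=C(SCc2ccc(Cl)cc2)N1` arises from compound 2 by 4-chlorophenyl in place of 3-chlorophenyl on a saturated chain carbon bound to a sulfur. Within the data shown here, the only measured step that bears on this change is a number 4.1 percentage points lower from compound 1 to compound 2 (within the scatter), which also exchanged one chlorophenyl for another at the same place and stayed within the scatter. The expected step of a number 1.9 percentage points higher from compound 2 to compound 3 (within the scatter) is therefore none beyond the scatter. Compound 3 is estimated to give 4.5%, with an expected range from -5% to 14%.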

Compound 3, a percentage reported as inhibition, in the whole organism at one dose (the size of the read-out at that dose, not a potency): 29.4%
Estimate against measurement, compound 3: 24.9 percentage points below, and the stated range ends below it.
By their numbers in this assay, from the lowest: compounds 2 and 1 (each within the scatter of the next); then compound 3.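

On a saturated chain carbon bound to a sulfur, the position of the chlorine on the phenyl ring can decide the result: 4-chlorophenyl brings a number 26.8 percentage points higher from compound 2 to compound 3 (beyond the scatter) and a number 22.7 percentage points higher from compound 1 to compound 3 (beyond the scatter) in the same series, while 2-chlorophenyl and 3-chlorophenyl remain within the scatter of each other. An exchange between chlorophenyl isomers at this place therefore need not be a small step. Nothing available accounts for this difference. Open, as far as these compounds go, is whether 4-fluorobenzyl, 4-methoxybenzyl or unsubstituted benzyl on the sulfur would stand with compound 3 or with the other two compounds.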